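Methyl in Place of Hydrogen: From Compound 2 to Compound 4

The source may report more compounds than this note shows. Statements on the series, on what has been measured and on what is new or still open speak of the compounds shown alone.

Three compounds have been measured in a functional assay on T47D cells (Homo sapiens) for inhibition, read by sulforhodamine B assay, with a stated time of 48 h; on this read-out higher numbers stand for weaker inhibition of growth and lower numbers for stronger inhibition of growth:

Compound 1 `COC(=O)[C@@]1(C)CCC=C2[C@@H]1CC[C@@H](C)[C@]2(C)Cc1c[nH]c2ccc(F)cc12` gives 3900 nM.
Compound 2 `COC(=O)[C@@]1(C)CCC=C2[C@@H]1CC[C@@H](C)[C@]2(C)Cc1c[nH]c2ccc(OC)cc12` gives 3700 nM.
Compound 3 `COC(=O)[C@@]1(C)CCC=C2[C@@H]1CC[C@@H](C)[C@]2(C)Cc1c[nH]c2ccc(C(F)(F)F)cc12` gives 15000 nM.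

Compound 2 has the lowest of the three numbers, but its margin over compound 1 is slight: a 1.1-fold lower number from compound 1 to compound 2 (0.02 log units; within the scatter), a gap within the usual scatter, so the two cannot be ranked. The gap to compound 3 is real: a 4.1-fold higher number from compound 2 to compound 3 (0.61 log units; beyond the scatter), and likewise a 3.8-fold higher number from compound 1 to compound 3 (0.59 log units; beyond the scatter). Both of those steps swap a group on an aromatic carbon of the same six-membered ring.

Compound 4 `COC(=O)[C@@]1(C)CCC=C2[C@@H]1CC[C@@H](C)[C@]2(C)Cc1c(C)[nH]c2ccc(OC)cc12` differs from compound 2 elsewhere: methyl in place of hydrogen on an aromatic carbon. The new methyl sits on an aromatic carbon of a five-membered aromatic ring with one nitrogen, part of a fused system of two rings, next to the ring nitrogen and next to the ring atom that bears a large group. For the measured compounds named here, none of the measured steps touches this position, so nothing in the set speaks directly to how this assay will respond. With no evidence either way, the expectation is a step of modest size at most, no change at the digits printed from compound 2 to compound 4 (within the scatter), not clearly beyond the scatter. The estimated value for compound 4 is therefore 3700 nM, with a likely range from 1500 nM to 9000 nM.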

Compound 4, concentration for 50% growth inhibition: 15000 nM
Compound 4: the middle estimate sits 4.1-fold (0.61 log units) below what was measured; measured number outside the range, above it.
By their numbers in this assay, from the lowest: compounds 2 and 1 (each within the scatter of the next); then compounds 3 and 4 (each within the scatter of the next).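

The added methyl shows that this position is not silent: in this assay, placing one heavy atom on an aromatic carbon of the five-membered aromatic ring with 1 nitrogen gives a 4.1-fold higher number from compound 2 to compound 4 (0.61 log units; beyond the scatter) and so weaker inhibition of growth. The earlier steps shown here changed only a group on the six-membered ring, so they could not show that the read-out also responds to a change on the five-membered ring. This small addition moves the number about as far as the swap of methoxy for trifluoromethyl, which gives a 4.1-fold higher number from compound 2 to compound 3 (0.61 log units; beyond the scatter) as a step, although no measurement at hand bears on what lies behind the change at the methyl position.

Methyl is the only group shown here in place of the hydrogen, so it remains open how this assay would respond to an ethyl chain, a chlorine atom or an amine on this same carbon. As far as these compounds go, it is also open whether methyl here would shift the number in the same way with fluoro rather than methoxy on the six-membered ring.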